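Swapping a cyclopropyl group for a methoxymethyl on the core

The compounds below may be only part of what the source reports. "The series", "measured", "known", "first", "only" and "open" are said of these compounds alone.

Measured so far:
compound 1, `CCCC(C1CC1)n1c(=O)c(C)nc2c(-c3ccc(Cl)cc3Cl)ccnc21`: 4.3 nM
compound 2, `CC[C@@H](C1CC1)n1c(=O)c(C)nc2c(-c3ccc(Cl)cc3Cl)ccnc21`: 7.4 nM

In a functional assay for antagonist activity at corticotropin-releasing factor receptor 1 (Rattus norvegicus) (a lower number here means a stronger inhibitor, a higher number a weaker inhibitor), compound 1 gives 4.3 nM and compound 2 gives 7.4 nM. Going by the values given here, compound 2 therefore holds the higher of the two numbers, but the one step that joins them, a 1.7-fold higher number from compound 1 to compound 2 (0.24 log units; within the scatter), lies within the scatter, so the two compounds are not told apart by these data.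

Compound 3, `CC[C@H](COC)n1c(=O)c(C)nc2c(-c3ccc(Cl)cc3Cl)ccnc21`, has not been measured. It differs from compound 2 in one place: 1-(methoxymethyl)propyl in place of 1-cyclopropylpropyl on an aromatic nitrogen. Among the compounds with values here, the only measured step concerns the length of the chain on this nitrogen and changed little; no measured pair shows what happens when the ring is replaced by an oxygen-bearing chain of the same size. The expectation for compound 3 is therefore a small step, a 1.6-fold higher number from compound 2 to compound 3 (0.21 log units; within the scatter), leaning slightly towards a higher number, with a wide range. Compound 3 is estimated at 12 nM, between 3 nM and 50 nM.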

Compound 3, half-maximal inhibitory concentration: 4 nM
Compound 3: the middle estimate sits 3.0-fold (0.48 log units) above what was measured, within the range that was stated.
By their numbers in this assay, from the lowest: compounds 3, 1 and 2 (each within the scatter of the next).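

In this assay the change to 1-(methoxymethyl)propyl in place of 1-cyclopropylpropyl on the aromatic nitrogen gives a 1.9-fold lower number from compound 2 to compound 3 (0.27 log units; within the scatter) and the comparison with the longer cyclopropyl chain gives a 1.1-fold lower number from compound 1 to compound 3 (0.03 log units; within the scatter). The three-membered carbon ring can therefore be replaced by an open chain with the same number of heavy atoms and a hydrogen-bond acceptor, with no difference that these data can detect. No measurement available here bears on why the number stays within the scatter.

The compounds shown leave open how much more change this position accepts. A longer chain ending in methoxy, or an amine or a carboxylic acid in place of the methoxy, could give a clearly different number.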